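Replacing the Cyclobutyl Ring with Two Methyl Groups

The source may report more compounds than this note shows. Statements on the series, on what has been measured and on what is new or still open speak of the compounds shown alone.

Of the compounds shown here, three built on one shared core have been tested in a functional assay on the whole organism with Rattus norvegicus as the target, in the maximal electroshock model; on this read-out lower numbers stand for an effect already at smaller amounts and higher numbers for an effect only at larger amounts of compound. Compound 1 `CCNc1ncnc2c1ncn2Cc1ccccc1F` gives 4.9 mg/kg, and compound 2 `CCCNc1ncnc2c1ncn2Cc1ccccc1F` gives 5.1 mg/kg; the step of a 1.0-fold higher number from compound 1 to compound 2 (0.02 log units; within the scatter) shows that the extra chain carbon makes no difference that can be told apart from repeat measurements. Compound 3 `Fc1ccccc1Cn1cnc2c(NC3CCC3)ncnc21` gives 33 mg/kg, the highest number of the three: the step of a 6.7-fold higher number from compound 1 to compound 3 (0.83 log units; beyond the scatter) and the step of a 6.5-fold higher number from compound 2 to compound 3 (0.81 log units; beyond the scatter) both show that the cyclobutyl group on the nitrogen calls for a clearly larger dose than either open chain.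

Compound 4 `CN(C)c1ncnc2c1ncn2Cc1ccccc1F` differs from compound 3 by dimethylamino in place of cyclobutylamino on an aromatic carbon. The two measured steps that bear on this change both involve the same nitrogen, and both mark the cyclobutyl group as the one that raises the dose, so taking it away is expected to bring the number back down. Within the data shown here, no measured pair, however, tells what happens when the hydrogen-bond donor on that nitrogen is lost, so the expectation is held loosely. Compound 4 is therefore expected to give 10 mg/kg, with a range from 4 mg/kg to 30 mg/kg, a step of a 3.3-fold lower number from compound 3 to compound 4 (0.52 log units; beyond the scatter) that is expected to run downward.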

Compound 4, dose for half-maximal effect: 8.8 mg/kg
Beside the measured number, compound 4's estimate is 1.1-fold (0.06 log units) above it; low and high end bracket the measured number.
By their numbers in this assay, from the lowest: compounds 1, 2 and 4 (each within the scatter of the next); then compound 3.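

In this assay, among these compounds, the step of a 3.8-fold lower number from compound 3 to compound 4 (0.57 log units; beyond the scatter) shows that a nitrogen carrying two methyl groups and no hydrogen-bond donor need not call for the larger dose seen with cyclobutylamino, a question the earlier compounds could not address, as all of them keep that donor. The steps of a 1.7-fold higher number from compound 2 to compound 4 (0.24 log units; within the scatter) and a 1.8-fold higher number from compound 1 to compound 4 (0.25 log units; within the scatter) both lie within the scatter, so in this assay dimethylamino cannot be told apart from the propylamino and ethylamino groups, and among the four compounds only cyclobutylamino stands apart. Nothing available explains these differences or links them to any property of the groups.

The compounds shown leave open whether the ring itself or some other feature of cyclobutylamino goes with the higher number, and cyclopropylamino, cyclopentylamino or a pyrrolidine ring, which would tie the two carbon arms of dimethylamino together, could help to separate these possibilities. They also leave open how far the open chains can be changed at this nitrogen, for instance with a longer butyl chain, a branched isopropyl group or a plain unsubstituted amino group.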